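Aryl to Alkyl Thiourea Swap in an Electroshock Series

A few compounds are considered here, and "the series" means these few. Any claim that something is new, unique, unknown or untested is made for them only; others in the source may bear on it.

Measured compounds and their values:
compound 1, `COc1cc2c(cc1OC)C(=O)C(CC1CCN(C(=S)Nc3ccccc3)CC1)C2`: 100 mg/kg
compound 2, `COc1cc2c(cc1OC)C(=O)C(CC1CCN(C(=S)Nc3ccccc3C)CC1)C2`: 100 mg/kg
compound 3, `COc1cc2c(cc1OC)C(=O)C(CC1CCN(C(=S)Nc3ccc(Cl)cc3)CC1)C2`: 30 mg/kg

In a functional assay on the whole organism (strain Swiss albino) with Mus musculus as the target, in the maximal electroshock model, with a stated time of 0.5 h (a lower number here means that less compound is needed, a higher number that more compound is needed for the effect), compound 3 gives 30 mg/kg, the lowest of the three numbers. Compound 1 gives 100 mg/kg and compound 2 gives 100 mg/kg, and the two steps toward compound 3, a 3.3-fold lower number from compound 1 to compound 3 (0.52 log units; beyond the scatter) and a 3.3-fold lower number from compound 2 to compound 3 (0.52 log units; beyond the scatter), are both beyond the scatter, so compound 3 stands alone at the favourable end. The step of no change at the digits printed from compound 1 to compound 2 (within the scatter) shows that the methyl made no difference.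

Compound 4, `CCCCNC(=S)N1CCC(CC2Cc3cc(OC)c(OC)cc3C2=O)CC1`, has not yet been measured. It differs from compound 3 in this way: butyl in place of 4-chlorophenyl on an amide-type nitrogen. Among the compounds with values here, no measured step covers an aromatic group giving way to a chain; the only relevant pattern is that the chloro on the aromatic ring carried the gain from compound 1 to compound 3, and that gain leaves with the 4-chlorophenyl. Compound 4 is therefore expected to give a higher number in this assay, around the level of compound 1, with the estimated step being a 3.3-fold higher number from compound 3 to compound 4 (0.52 log units; beyond the scatter). The expected value for compound 4 is 100 mg/kg, within 30 mg/kg to 300 mg/kg.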

Compound 4, minimum effective dose: 100 mg/kg
The estimate for compound 4 equals the measured number at the digits printed; low and high end bracket the measured number.
By their numbers in this assay, from the lowest: compound 3; then compounds 1, 2 and 4 (each within the scatter of the next).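

In this assay, the aromatic ring on this amide-type nitrogen proves dispensable as such: butyl in place of phenyl gives no change at the digits printed from compound 1 to compound 4 (within the scatter), and butyl in place of 2-methylphenyl gives no change at the digits printed from compound 2 to compound 4 (within the scatter). The lower number therefore belongs to the 4-chlorophenyl group alone among these four compounds, not to aryl groups in general, as the change to butyl gives a 3.3-fold higher number from compound 3 to compound 4 (0.52 log units; beyond the scatter) while phenyl and 2-methylphenyl stay level with butyl. Nothing available accounts for this difference.

On these data alone, it remains open whether a longer chain such as octyl, or a saturated ring such as cyclohexyl, on this nitrogen could reach the number of compound 3. Also open, as far as these compounds go, is whether a 4-bromophenyl or 4-methoxyphenyl group would behave like the 4-chlorophenyl group.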